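This account rests on a few compounds, and the source may have more. Where it says the series, first, only, none or still open, it means among the compounds named here.

Series notes. Compound 1 `O=Cc1ccc(-c2cn3ccnc3c(-c3ccc4ncn(C5CCCCC5)c4c3)n2)cc1` in a functional assay on OVCAR-4 cells (Homo sapiens) for inhibition, read by sulforhodamine B assay, with a stated time of 48 h, tested at 10 uM (on this read-out lower numbers stand for less inhibition and higher numbers for more inhibition at the one concentration tested (going by the name of the read-out)), gives 16.9%. Compound 2 `c1ccc2c(-c3cn4ccnc4c(-c4ccc5ncn(C6CCCCC6)c5c4)n3)cccc2c1` carries naphthalen-1-yl in place of 4-formylphenyl on an aromatic carbon; in this assay compound 2 gives 19.7%, a step of a number 2.8 percentage points higher from compound 1 to compound 2 (within the scatter). Compound 3 `O=Cc1ccc(-c2cn3ccnc3c(-c3ccc4ncn(Cc5ccccc5)c4c3)n2)cc1` differs from compound 1 in its core by benzyl in place of cyclohexyl on an aromatic nitrogen; in this assay compound 3 gives 16.9%, a step of no change at the digits printed from compound 1 to compound 3 (within the scatter). Compound 4 `c1ccc(Cn2cnc3ccc(-c4nc(-c5cccc6ccccc56)cn5ccnc45)cc32)cc1` has not been measured. It differs from compound 3 by naphthalen-1-yl in place of 4-formylphenyl on an aromatic carbon, which is the same change as that made from compound 1 to compound 2, and the surroundings of the place are described in the same words for both pairs, so only the core differs, as described between compound 1 and compound 3. For the measured compounds named here, the one measured instance of the change, from compound 1 to compound 2, moved the read-out by an amount within the scatter, and the core difference itself left the read-out unchanged at the digits given between compound 1 and compound 3. The step from compound 3 to compound 4 is therefore expected to be about a number 2.8 percentage points higher from compound 3 to compound 4 (within the scatter), resting on the measured step of a number 2.8 percentage points higher from compound 1 to compound 2 (within the scatter). Compound 4 is expected to give about 19.7% in this assay, with a likely range from 8% to 32%.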

Compound 4, a percentage reported as inhibition, at one concentration (the size of the read-out at that concentration, not a potency): 7.88%
The estimate for compound 4 lay 11.8 percentage points above the measured number; the whole stated range lies above it.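

In this assay, naphthalen-1-yl in place of 4-formylphenyl gives a number 9 percentage points lower from compound 3 to compound 4 (within the scatter), and this step does not differ beyond the scatter from the one on the core of compound 1: the same change on two cores in this assay, a number 2.8 percentage points higher (within the scatter) from compound 1 to compound 2 and a number 9 percentage points lower (within the scatter) from compound 3 to compound 4, 11.8 percentage points apart, within the scatter of two such steps. Benzyl in place of cyclohexyl gives a number 11.8 percentage points lower from compound 2 to compound 4 (beyond the scatter), which is beyond the scatter as a single step, yet it also does not differ beyond the scatter from its earlier counterpart: the same change on two cores in this assay, no change at the digits printed (within the scatter) from compound 1 to compound 3 and a number 11.8 percentage points lower (beyond the scatter) from compound 2 to compound 4, 11.8 percentage points apart, within the scatter of two such steps. The two cores therefore give no evidence that either change behaves differently from one core to the other, but with a single pair per core and one concentration, this does not show that the steps are equal or that either change transfers reliably across the series.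

The compounds shown leave open what an amine or a carboxylic acid would give on the aromatic carbon that carries 4-formylphenyl or naphthalen-1-yl. They also leave open what a longer chain would give on the aromatic nitrogen that carries cyclohexyl or benzyl.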